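A few compounds are considered here, and "the series" means these few. Any claim that something is new, unique, unknown or untested is made for them only; others in the source may bear on it.

Measured so far in a physicochemical assay for lipophilicity; a lower number here means a more polar compound, a higher number a more lipophilic compound:
- compound 1 `CC(=O)Nc1ccc(OC(=S)Nc2ccc(Nc3ccc([N+](=O)[O-])cc3)cc2)cc1`: 4.32
- compound 2 `CC(=O)Nc1ccc(OC(=S)Nc2ccc(Sc3ccc(C(F)(F)F)cc3)cc2)cc1`: 5.96
- compound 3 `Oc1ccc(OC(=S)Nc2ccc(Oc3ccc(C(F)(F)F)cc3)cc2)cc1`: 6.11

Compound 3 holds the highest of the three numbers in this assay. Its nearest neighbour is compound 2, whose value sits within the scatter of that of compound 3, so the two cannot be ranked against each other. Compound 1 lies furthest away, beyond the scatter, and is the only one of the three carrying a nitro group; it differs from compound 3 in more than one place, so no single step can be read from the pair.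

Compound 4 `O=[N+]([O-])c1ccc(Oc2ccc(NC(=S)Oc3ccc(O)cc3)cc2)cc1` has not been measured yet. It differs from compound 3 in one respect: nitro in place of trifluoromethyl on an aromatic carbon. Going by the values given here, no step between two measured compounds isolates this exchange.

In this assay a step downward, beyond the scatter, is expected from compound 3 to compound 4, partly because compound 1 with its nitro group gives 4.32, though that comparison is confounded by the other differences. The expected step is a number 1.11 log units lower from compound 3 to compound 4 (beyond the scatter). For compound 4 the estimate in this assay is 5, with a range from 4.4 to 5.6.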

Compound 4, partition coefficient: 5.01
For compound 4 the middle estimate is 0.01 log units below the measured one; low and high end bracket the measured number.
By their numbers in this assay, from the lowest: compound 1; then compound 4; then compounds 2 and 3 (each within the scatter of the next).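

In this assay, going by these compounds alone, nitro in place of trifluoromethyl on an aromatic carbon, para to a large group, gives a number 1.10 log units lower from compound 3 to compound 4 (beyond the scatter), and this is the only step that isolates a single exchange with the rest of the structure held constant. Within the data shown here, the position is therefore not indifferent to which of these two groups it carries, something the earlier compounds could not show, as they differ from one another in more than one place. No measurement at hand accounts for the size of this step.

From the compounds shown here alone, whether the same exchange gives a step of similar size on the core of compound 1 or the core of compound 2 remains open, as a single pair on a single core cannot show whether the step carries over. Also open, going by these compounds, is how a nitrile, an amine, a carboxylic acid or a plain hydrogen at this position would stand against nitro and trifluoromethyl in this assay, so the two groups compared here mark only two points on this position.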